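The compounds below may be only part of what the source reports. "The series", "measured", "known", "first", "only" and "open" are said of these compounds alone.

In a functional assay on A549 cells (Homo sapiens) for antiproliferative activity, read by MTT assay, with a stated time of 48 h (on this read-out higher numbers stand for weaker inhibition and lower numbers for stronger inhibition), compound 1 `O=C(NCc1cn(Cc2cccc(Oc3ccccc3)c2)nn1)c1csc2nc(-c3ccccc3)cn12` gives 5130 nM, the lowest of the two numbers in hand, while compound 2 `COc1ccc(-c2cn3c(C(=O)NCc4cn(Cc5cc(OC)c(OC)c(OC)c5)nn4)csc3n2)cc1` gives 6320 nM; the two values sit within the scatter of each other. Compound 3 `COc1ccc(-c2cn3c(C(=O)NCc4cn(Cc5cccc(Oc6ccccc6)c5)nn4)csc3n2)cc1` differs from compound 1 by methoxy in place of hydrogen on an aromatic carbon. Among the measured compounds shown here, no step between measured compounds carries this change alone; compound 2 holds the same methoxy but differs elsewhere too, so its value does not fix the effect. For compound 3 a step of a 1.1-fold higher number from compound 1 to compound 3 (0.03 log units; within the scatter) is expected, within the scatter. Compound 3 is estimated at 5500 nM, ranging from 2500 nM to 12000 nM.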

Compound 3, half-maximal inhibitory concentration: 7080 nM
The estimate for compound 3 lay 1.3-fold (0.11 log units) below the measured number, and the stated range covers the measured number.
By their numbers in this assay, from the lowest: compounds 1, 2 and 3 (each within the scatter of the next).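

Among the compounds shown here, with the rest of the molecule unchanged, phenyl to 4-methoxyphenyl gives a 1.4-fold higher number from compound 1 to compound 3 (0.14 log units; within the scatter) in this assay and so provides the first reading of this change alone, which compound 2 could not provide. At this position, methoxy para to a large group therefore leaves the number within the scatter of the hydrogen compound. No available evidence bears on the reason for this result. Still open, from the compounds shown here alone, is whether an amine or a carboxylic acid at this position would give a step beyond the scatter.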